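This account rests on a few compounds, and the source may have more. Where it says the series, first, only, none or still open, it means among the compounds named here.

Measured so far in a physicochemical assay for lipophilicity, read by HPLC, measured as octanol-water partition; on this read-out lower numbers stand for lower lipophilicity and higher numbers for higher lipophilicity:
- Compound 1, `O=C1O[C@@H](CO)CN1c1ccc(-n2cc(-c3ccccn3)cn2)c(F)c1`: 1.67
- Compound 2, `O=CNC[C@H]1CN(c2ccc(-n3cc(-c4ccccn4)cn3)c(F)c2)C(=O)O1`: 1.19

Among the measured compounds shown here, compound 2 gives the lower of the two numbers in this assay; the only comparison available is the drop of a number 0.48 log units lower from compound 1 to compound 2 (beyond the scatter), which replaced a hydroxy with a formylamino group on the side chain of the shared core.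

Compound 3, `CCNC(=O)NC[C@H]1CN(c2ccc(-n3cc(-c4ccccn4)cn3)c(F)c2)C(=O)O1`, differs from compound 2 at the end of that same side chain: ethylamino in place of hydrogen on a carbonyl carbon. Read one bond further out, this turns the formylamino group into an (ethylcarbamoyl)amino group.

For the measured compounds named here, no measured step here exchanges a hydrogen for an ethylamino group, so the step from compound 1 to compound 2 gives only indirect guidance: it shows that this side chain end is a place where changes have moved the number by a modest amount. For compound 3 the expected step is a number 0.11 log units higher from compound 2 to compound 3 (within the scatter), a change not beyond the scatter. The estimate for compound 3 is therefore 1.3, with a range from 0.8 to 1.8.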

Compound 3, partition coefficient: 2.45
For compound 3 the middle estimate is 1.15 log units below the measured one; measured number above the stated range.
By their numbers in this assay, from the lowest: compound 2; then compound 1; then compound 3.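

With ethylamino in place of hydrogen on a carbonyl carbon, the number in this assay rises by a large step (a number 1.26 log units higher from compound 2 to compound 3 (beyond the scatter)), so this end of the side chain can move the read-out much further than the earlier formylamino change showed. Against hydroxy, the two groups shown now fall on opposite sides: formylamino gives a lower number (a number 0.48 log units lower from compound 1 to compound 2 (beyond the scatter)), while (ethylcarbamoyl)amino gives a higher one (a number 0.78 log units higher from compound 1 to compound 3 (beyond the scatter)), so a change at this place does not have one fixed direction across these compounds. Nothing available accounts for the size of the rise.

The compounds shown leave open how the number responds to a plain amino group or a longer propylamino chain on that carbonyl carbon. They also leave open whether an ethyl group placed there without the nitrogen would give a step of similar size.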